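The compounds below may be only part of what the source reports. "The series", "measured", "known", "first", "only" and "open" are said of these compounds alone.

Measured compounds:
compound 1 `N#C/N=C(\NCCCCc1ccccc1)NCCCc1c[nH]cn1`: 5.03
compound 2 `N#C/N=C(/NCCCc1c[nH]cn1)NCCC(c1ccccc1)c1ccccc1`: < 5

In an in vitro functional assay on Sf9 cells for antagonist activity at histamine H2 receptor (Homo sapiens) (on this read-out lower numbers stand for lower potency and higher numbers for higher potency (the scale is a negative logarithm)), compound 1 gives 5.03. Compound 2 is reported only as a limit of the method in this assay, < 5, and so has no number of its own. Going by the values given here, that limit is the one described as the limit of < 5 in this assay, at which 1 of the 2 values shown sits, which places compound 2 at the lower edge of the values shown, with the one numbered value, that of compound 1, sitting just above it.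

Compound 3 `N#C/N=C(/NCCCCc1c[nH]cn1)NCCC(c1ccccc1)c1ccccc1` has not yet been measured in this assay. Compared with compound 2 it carries (1H-imidazol-4-yl)methyl in place of 1H-imidazol-4-yl on a saturated chain carbon, three bonds along the chain from an amine nitrogen. Among the compounds with values here, no pair of measured compounds differs in exactly this place, so the data give no measured size for such a step. A change of this kind, the same two phenyl-bearing chain on the other side being kept, is expected to shift the read-out little, probably within the scatter, in either direction. Compound 3 is therefore expected to give about 5, between 4.3 and 5.7, an expected step of a number no lower from compound 2 to compound 3 (the limit leaves the size open).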

Compound 3, negative logarithm of the antagonist equilibrium constant: 5
Compound 3: the middle estimate sits on the measured number at the digits printed; the range from low to high includes it.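

Compound 3 gives this side of the series its first number in this assay, where the earlier compound with the same two phenyl-bearing chain offered only a limit. With (1H-imidazol-4-yl)methyl in place of 1H-imidazol-4-yl on a saturated chain carbon, three bonds along the chain from an amine nitrogen, the result is a number no lower from compound 2 to compound 3 (the limit leaves the size open). The change thus does not lower the read-out, but the size of the step cannot be read, as compound 2 stands only at a limit: the limit of < 5 in this assay, at which 1 of the 3 values shown sits.

The compounds shown leave open whether a chain longer than 4-(1H-imidazol-4-yl)butyl would change the read-out at all. They also leave open what a primary amine in place of the 1H-imidazol-4-yl ring would do on this same chain.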